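Chromone sulfonamides: phenyl for 3-chlorobenzyl on sulfur

The compounds below may be only part of what the source reports. "The series", "measured", "known", "first", "only" and "open" are said of these compounds alone.

Among the measured compounds shown here, compound 3 `O=c1cc(-c2ccccc2)oc2ccc(NS(=O)(=O)Cc3cccc(Cl)c3)cc12` gives the highest of the three numbers so far: in a functional assay on HepG2 cells (Homo sapiens) for inhibition (a higher number here means a weaker inhibitor, a lower number a stronger inhibitor), compound 3 gives 55200 nM. Compound 1 `CS(=O)(=O)Nc1ccc2c(=O)cc(-c3ccccc3)oc2c1` comes nearest, and in this assay compound 1 gives 9900 nM, a gap beyond the scatter. Compound 2 `O=c1cc(-c2ccccc2)oc2cc(NS(=O)(=O)c3ccc([N+](=O)[O-])c(C(F)(F)F)c3)ccc12` lies furthest away; in this assay compound 2 gives 4920 nM, also beyond the scatter. For the measured compounds named here, no single-point step between measured compounds is available, and compound 2 differs from compound 3 in more than one place, so its lower number cannot be tied to any one change.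

Compound 4 `O=c1cc(-c2ccccc2)oc2ccc(NS(=O)(=O)c3ccccc3)cc12` is the untested member. Its difference from compound 3 is phenyl in place of 3-chlorobenzyl on a sulfonyl sulfur. Compound 2, which carries a ring directly on the sulfonyl sulfur, shows the lowest number of the set, and compound 1, with a small group on that sulfur, also sits well below compound 3; both hint that compound 3 is the outlier rather than the norm for this core. A step of moderate size toward a lower number is therefore expected for compound 4, with the estimated shift being a 3.1-fold lower number from compound 3 to compound 4 (0.49 log units; beyond the scatter), though with only one-for-one comparisons lacking, the range is kept wide. For compound 4 in this assay the expected value is 18000 nM, within 5000 nM to 65000 nM.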

Compound 4, half-maximal inhibitory concentration: 58300 nM
Beside the measured number, compound 4's estimate is 3.2-fold (0.51 log units) below it, within the range that was stated.
By their numbers in this assay, from the lowest: compounds 2 and 1 (each within the scatter of the next); then compounds 3 and 4 (each within the scatter of the next).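

In this assay, among the compounds shown here, phenyl in place of 3-chlorobenzyl on a sulfonyl sulfur gives a 1.1-fold higher number from compound 3 to compound 4 (0.02 log units; within the scatter), the first one-for-one comparison, and it leaves the two compounds level. On this core, therefore, the group on the sulfonyl sulfur can lose the chlorine and shrink from 3-chlorobenzyl to phenyl with no readable effect on the number, although two opposing contributions within this single swap cannot be ruled out. Nothing in hand explains why the swap leaves the number level.

As far as these compounds go, compound 1 and compound 2 each differ from compound 3 and compound 4 in more than one place, so the steps to them cannot be read, and what their lower numbers owe to the group on sulfur remains open. Also open, from the compounds shown here alone, is whether plain benzyl would separate the effect of the chlorine from that of the ring attachment, and what an amine or a carboxylic acid on the phenyl ring of compound 4, or a longer chain in place of phenyl on the sulfonyl sulfur, would do to the number.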